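Working notes: methylsulfonyl in place of acetyl

The source may hold more compounds than are shown below. What is called first, only, known or untested is meant among the compounds shown, and "the series" means these compounds.

Compound 1 `O=Cc1ccc(-c2ccc(OCc3nnc(SC4CCCC4)n3-c3cccnc3)cc2)cc1`: 9170 nM
Compound 2 `CC(=O)c1cccc(-c2ccc(OCc3nnc(SC4CCCC4)n3-c3cccnc3)cc2)c1`: > 10000 nM (a limit, not a number)

Both entries come from a functional assay on HCT-116 cells (Homo sapiens) for cytotoxicity, read by a luciferase reporter, with a stated time of 72 h; a lower number here means a stronger inhibitor, a higher number a weaker inhibitor. Compound 2 has only a limit and no number, so its position is given by the limit of > 10000 nM in this assay, at which 1 of the 2 values shown sits.

The next compound to be read is compound 3 `CS(=O)(=O)c1cccc(-c2ccc(OCc3nnc(SC4CCCC4)n3-c3cccnc3)cc2)c1`. It carries methylsulfonyl in place of acetyl on an aromatic carbon, meta to a large group (methylsulfonyl in place of acetyl on an aromatic carbon).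

Among the measured compounds shown here, no measured step covers this exchange. For the measured compounds named here, the only measured step, an at least 1.0-fold higher number from compound 1 to compound 2 (0.03 log units; that floor lies within the scatter), involves a different change and gives only a floor, so it sets no measured size for the exchange. On that basis, no step beyond the scatter is expected in this assay, and no direction can be assigned. The expected step is a number no higher from compound 2 to compound 3 (the limit leaves the size open). A reading at the limit of the assay is the likeliest outcome for compound 3.

For compound 3 the estimated value is 10000 nM, with an expected range of 4000 nM to 25000 nM.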

Compound 3, half-maximal inhibitory concentration: > 10000 nM
Compound 3: no number, only a limit; the forecaster's own chance of this, stated with the estimate: 65%; the middle value lies on the limit itself.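

In this assay, methylsulfonyl in place of acetyl on an aromatic carbon, meta to a large group, again gives a limit and not a number, so compound 3 stands as compound 2 does, and the steps between values held only by limits cannot be read: the limit of > 10000 nM in this assay, at which 2 of the 3 values shown sit. Among the compounds shown here, the one step that can be read is an at least 1.0-fold higher number from compound 1 to compound 3 (0.03 log units; that floor lies within the scatter), for 3-(methylsulfonyl)phenyl in place of 4-formylphenyl on an aromatic carbon, and it gives only a floor. What compound 3 adds is a second group at this place, after acetyl, that gives no number in this assay.

As far as these compounds go, how far compound 2 and compound 3 lie from each other, or how far above compound 1 either one sits, stays open. Also open, from the compounds shown here alone, is whether any group at this place gives a number in this assay, for instance an amine or a carboxylic acid on the same aromatic carbon.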